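Amide variation from compound 2 to compound 3

The source may hold more compounds than are shown below. What is called first, only, known or untested is meant among the compounds shown, and "the series" means these compounds.

Compound 1 `CCNC(=O)CC1CCc2cc(OC)c(OC)cc21` gives 26% in a functional assay on the whole organism (strain Wistar) for inhibition, with Rattus norvegicus as the target, read by paw edema, with stated times of 60 min and 2 h, at a dose of 100 mg/kg by the oral route; a higher number here means more inhibition at the dose given (going by the name of the read-out), a lower number less inhibition.
Compound 2 `COc1cc2c(cc1OC)C(CC(=O)N1CCCCC1)CC2` gives 22% in this assay.

Compound 2 sits alongside compound 1 on the numbers shown, the step of a number 4 percentage points lower from compound 1 to compound 2 (within the scatter) being within the scatter. Compound 3 `COc1cc2c(cc1OC)C(CC(=O)N1CCNCC1)CC2` differs from compound 2 by piperazin-1-yl in place of piperidin-1-yl on a carbonyl carbon. Within the data shown here, the only measured step bearing on this is the earlier amide exchange at the same carbonyl carbon, a number 4 percentage points lower from compound 1 to compound 2 (within the scatter), which stayed within the scatter. Among the measured compounds shown here, no measured step introduces a hydrogen-bond donor, so the expectation rests on that one step alone: a change within the scatter is expected, no change at the digits printed from compound 2 to compound 3 (within the scatter). Compound 3 is estimated at 22% in this assay, with a range from 8% to 36%.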

Compound 3, a percentage reported as inhibition, in the whole organism at one dose (the size of the read-out at that dose, not a potency): 44%
Beside the measured number, compound 3's estimate is 22 percentage points below it, outside the stated range (above it).
By their numbers in this assay, from the lowest: compounds 2 and 1 (each within the scatter of the next); then compound 3.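

At the carbonyl carbon the amide group does matter in this assay: piperazin-1-yl in place of piperidin-1-yl gives a number 22 percentage points higher from compound 2 to compound 3 (beyond the scatter), and piperazin-1-yl in place of ethylamino gives a number 18 percentage points higher from compound 1 to compound 3 (beyond the scatter), so this position responds to a change of amide, which the earlier exchange had not shown. The entering ring differs from the leaving one by a second ring nitrogen, which carries the added hydrogen-bond donor and acceptor by count. Nothing available explains the rise.

Going by these compounds, whether the hydrogen on that ring nitrogen is needed stays open. A 4-methylpiperazin-1-yl or morpholin-4-yl group at the same carbonyl carbon would separate the ring nitrogen from its hydrogen.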